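This account rests on a few compounds, and the source may have more. Where it says the series, first, only, none or still open, it means among the compounds named here.

Three compounds have been measured in an assay on nucleic acid for inhibition of Nucleic Acid, read by fluorescence, tested at 100 uM; a lower number here means less inhibition, a higher number more inhibition at the concentration tested (going by the name of the read-out):

- compound 1, `CCCCC(O)Cn1cc(CN(C)CC2CCCCC2)nn1`: 47%
- compound 2, `CC(C)CCN(C)Cc1cn(CC(O)COC(=O)NCc2ccccc2)nn1`: 26%
- compound 3, `CN(Cc1cn(C2CCCCC2OC(=O)COc2ccccc2)nn1)CC1CCCCC1`: 37%

Compound 1 has the highest of the three numbers. Compound 3 sits closest, and the gap between compound 1 and compound 3 is within the usual scatter, so no order can be read between them. Compound 2 is the furthest, and its gap from compound 1 lies beyond the scatter.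

Compound 4, `CN(Cc1cn(CC(O)COCc2ccccc2)nn1)CC1CCCCC1`, has not yet been measured. It differs from compound 1 in one place: benzyloxy in place of propyl on a saturated chain carbon, two bonds along the chain from an oxygen on a saturated carbon. Going by the values given here, no pair of measured compounds isolates this change, so its size is not known from the data. Compound 4 keeps the same amine part as compound 1 and compound 3, the two that stand higher, while compound 2, which carries a different amine, gives the lowest number. On that basis the step from compound 1 to compound 4 is expected to be small, downward if anything, and not clearly beyond the scatter, so that compound 4 is estimated to give 40%, within 24% to 56%, a change of a number 7 percentage points lower from compound 1 to compound 4 (within the scatter).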

Compound 4, a percentage reported as inhibition, at one concentration (the size of the read-out at that concentration, not a potency): 6%
Compound 4: the middle estimate sits 34 percentage points above what was measured; measured number outside the range, below it.
By their numbers in this assay, from the lowest: compound 4; then compound 2; then compounds 3 and 1 (each within the scatter of the next).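

In this assay the position on a saturated chain carbon, two bonds along the chain from an oxygen on a saturated carbon, proves sensitive to what sits there. Placing benzyloxy there in place of propyl gives a number 41 percentage points lower from compound 1 to compound 4 (beyond the scatter) with the rest of the molecule unchanged, so this single change is enough to remove most of the inhibition. Nothing available explains why the number falls.

This one pair cannot show whether the fall goes with the aromatic ring, the added oxygen or simply the greater length of the group. A plain hexyl chain, a small methoxy group or a primary amine at this position would each help to separate these possibilities, and the compounds shown include none of them.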